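A Side Chain Swap on Compound 3

The source may report more compounds than this note shows. Statements on the series, on what has been measured and on what is new or still open speak of the compounds shown alone.

Of the compounds shown here, three have so far been measured in a functional assay on A-427 cells (Homo sapiens) for cytotoxicity, read by colorimetric assay and MTT assay (on this read-out lower numbers stand for stronger inhibition and higher numbers for weaker inhibition), and they give a single reading. Compound 1 (`COc1ccc2cc(-c3ccccc3)c(O)nc2c1`) gives 10000 nM in this test. Compound 2 (`COc1ccc(-c2cc3c(OC)ccc(OC)c3nc2O)cc1`) gives 10000 nM on the same read-out. Compound 3 (`COc1ccc(-c2cc3c(OC)cc(OC)cc3n(CC(=O)OCc3ccccc3)c2=O)cc1`) gives 10000 nM as well, so it stands level with compounds 1 and 2, and the numbers do not separate the three.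

The next compound is compound 4 (`CCN(CC)C(=O)CCn1c(=O)c(-c2ccc(OC)cc2)cc2c(OC)cc(OC)cc21`), which differs from compound 3 in one place, on a saturated chain carbon bound to an aromatic nitrogen. The difference is (diethylcarbamoyl)methyl in place of benzyloxycarbonyl on a saturated chain carbon bound to an aromatic nitrogen and the rest of the structure is unchanged. In short, (diethylcarbamoyl)methyl stands in place of benzyloxycarbonyl.

Going by the values given here, no two measured compounds differ in one place only, so the data hold no direct precedent for this swap. Among the compounds with values here, the only guide is the reading shared by all three measured compounds, including compound 3 at 10000 nM in this assay so far. No step beyond the scatter is therefore expected, in either direction. The expected change is no change at the digits printed from compound 3 to compound 4 (within the scatter) on this estimate. The estimate for compound 4 is 10000 nM with an expected range from 3000 nM to 20000 nM in this test.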

Compound 4, half-maximal inhibitory concentration: 10000 nM
Beside the measured number, compound 4's estimate shows no gap at the digits printed, within the range that was stated.
By their numbers in this assay, from the lowest: compounds 1, 2, 3 and 4 (each within the scatter of the next).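

In this assay, placing (diethylcarbamoyl)methyl in place of benzyloxycarbonyl on a saturated chain carbon bound to an aromatic nitrogen gives no change at the digits printed from compound 3 to compound 4 (within the scatter). This is the only pair shown that differs in one place, and it gives this position its first direct reading: the group that leaves holds a six-membered aromatic ring of carbon only, the group that enters holds no ring and carries a nitrogen, and the two readings do not separate. Nothing at hand accounts for this result or for the reading shared by the four compounds.

As far as these compounds go, what remains open is whether any group at this place can move the reading away from the level shared by all four compounds, for example a carboxylic acid, a primary amine or a longer chain ending in a morpholine ring. This single pair also leaves open whether the same swap would read the same way on a different core, such as that of compound 1 or compound 2.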